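The source may report more compounds than this note shows. Statements on the series, on what has been measured and on what is new or still open speak of the compounds shown alone.

The series is read in an assay on isolated protein for displacement of a labelled ligand from metabotropic glutamate receptor 5 (Homo sapiens), with a stated time of 60 min, tested at 1 uM; a higher number here means more inhibition at the concentration tested (going by the name of the read-out), a lower number less inhibition. Compound 1, `COc1ccc(S(=O)(=O)c2cnc3ccc(C)cc3c2N2CCC(C)CC2)cc1Cl`, gives 93% in this assay. Compound 2, `COc1ccc(S(=O)(=O)c2cnc3cc(F)ccc3c2N2CCC(C)CC2)cc1OC`, gives 83%. Compound 3, `COCC1CCN(c2c(S(=O)(=O)c3ccc(F)cc3)cnc3cc(F)ccc23)CC1`, gives 76.1%. Compound 3 therefore sits below compound 1 by a margin beyond the usual scatter, while its gap to compound 2 lies within the scatter, so nothing can be said about an order between compound 3 and compound 2. Among the compounds with values here, no pair of these three differs in a single place, so no measured single step is available to lean on.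

Compound 4, `COCC1CCN(c2c(S(=O)(=O)c3cc(F)cc(F)c3)cnc3cc(F)ccc23)CC1`, is the next compound. It departs from compound 3 in one place only:

3,5-difluorophenyl in place of 4-fluorophenyl on a sulfonyl sulfur

The change keeps the same ring and adds a second fluorine on it while the first moves from one position to two others. Within the data shown here, nothing among the measured compounds shows what such a change does in this assay, so the author can only expect, as a guess, that compound 4 stays close to compound 3, with no step beyond the scatter in either direction. For compound 4 the estimate in this assay is 74%, within a range from 58% to 88%, which corresponds to an expected step of a number 2.1 percentage points lower from compound 3 to compound 4 (within the scatter).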

Compound 4, a percentage reported as inhibition, at one concentration (the size of the read-out at that concentration, not a potency): 83%
Beside the measured number, compound 4's estimate is 9 percentage points below it, and the stated range covers the measured number.
By their numbers in this assay, from the lowest: compounds 3, 2, 4 and 1 (each within the scatter of the next, the first and the last beyond it).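

Within the data shown here, this is the first single-place step: in this assay, 3,5-difluorophenyl in place of 4-fluorophenyl on a sulfonyl sulfur gives a number 6.9 percentage points higher from compound 3 to compound 4 (within the scatter). At this position, then, the fluorine pattern on the phenyl ring can be altered and the fluorine count raised without a change that this read-out can separate from the usual scatter, so the two compounds must be treated as equal here. Nothing measured in the material at hand speaks to the reason for this outcome, and no explanation can be offered for it.

What the compounds shown leave open is how far this position can stray from a fluorinated phenyl, for example whether an amine or a carboxylic acid on that ring, or a simple alkyl chain on the sulfonyl sulfur in place of the ring, would keep the inhibition seen here. Going by these compounds, it also remains open whether compound 3 and compound 4 would differ in a full concentration series, as a reading at one concentration is not a potency.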